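The compounds below may be only part of what the source reports. "The series", "measured", "known", "first", "only" and "open" are said of these compounds alone.

Measured so far:
compound 1 `COCOc1cc(/C=C/C(=O)OCC(=O)Nc2ccc(OC)cc2)ccc1OCc1ccccc1`, > 200000 nM
compound 2 `O=C(COC(=O)/C=C/c1ccc(O)c(O)c1)NN1CCOCC1`, > 200000 nM

In a functional assay on HL-60 cells (Homo sapiens) for cytotoxicity, read by MTT assay, with a stated time of 72 h (on this read-out higher numbers stand for weaker inhibition and lower numbers for stronger inhibition), compound 1 gives only a limit, > 200000 nM. In this assay compound 2 likewise gives only a limit, > 200000 nM. Compound 2 thus stands at the limit of > 200000 nM in this assay, at which 2 of the 2 values shown sit, with no number of its own. Compound 3 `COc1ccc(NC(=O)COC(=O)/C=C/c2ccc(O)c(O)c2)cc1` is not yet measured; it differs from compound 2 by 4-methoxyphenyl in place of morpholin-4-yl on an amide-type nitrogen. For the measured compounds named here, no measured step exists between compounds here, so nothing beyond the scatter in this assay is expected in either direction. Compound 3 is expected to give roughly 250000 nM, between 100000 nM and 600000 nM, most probably again only a limit. The step that the limit leaves unreadable from compound 2 to compound 3 is expected to lie within the scatter.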

Compound 3, half-maximal inhibitory concentration: 72100 nM
The estimate for compound 3 lay 3.5-fold (0.54 log units) above the measured number, outside the stated range (below it).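

In this assay, the amide-type nitrogen proves sensitive to its substituent: 4-methoxyphenyl in place of morpholin-4-yl gives an at least 2.7-fold lower number from compound 2 to compound 3 (0.44 log units; beyond the scatter). Compound 3 is the only compound shown with a number rather than a limit, so activity can now be read at this position. The full size of the step remains unreadable because compound 2 has only a limit: the limit of > 200000 nM in this assay, at which 2 of the 3 values shown sit.

Whether the aromatic ring or its methoxy group accounts for the change remains open. Plain phenyl or 4-hydroxyphenyl on this nitrogen would separate the two.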